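A few compounds are considered here, and "the series" means these few. Any claim that something is new, unique, unknown or untested is made for them only; others in the source may bear on it.

Three compounds that share a three-carbon linker between two rings have been run in an in vitro ADME assay on microsomes from liver (Simiiformes); on this read-out lower numbers stand for a shorter-lived compound and higher numbers for a longer-lived compound. Compound 1 `Cc1cc(-c2noc(C3CC3)n2)cc(C)c1OCCCc1cc(C2CC2)no1` gives > 2.5 h, which is a limit of the assay rather than a number. Compound 2 `CCOc1cc(CCCOc2c(C)cc(-c3noc(C4CC4)n3)cc2C)on1` likewise gives the limit > 2.5 h. Compound 3 `CCOc1nc(-c2cc(C)c(OCCCc3cc(C)no3)c(C)c2)no1` also stops at the limit > 2.5 h. Between compound 2 and compound 1 the change cyclopropyl in place of ethoxy on an aromatic carbon makes a step that the two limits leave unreadable from compound 2 to compound 1. Compound 4 `Cc1cc(CCCOc2c(C)cc(-c3noc(C4CC4)n3)cc2C)on1` is not yet measured; from compound 3 it carries cyclopropyl in place of ethoxy on an aromatic carbon, the same kind of change, occurring twice among the compounds shown, though here the place is a five-membered aromatic ring with 2 nitrogen and 1 oxygen, next to the ring oxygen, whereas before it was a ring with 1 nitrogen and 1 oxygen, two ring bonds from the ring oxygen. How the core of compound 3 differs from the core of compound 2 is not broken down here. Because (the limit of > 2.5 h in this assay, at which 3 of the 3 values shown sit), compound 4 is expected to reach 4 h. The expected step is then a step that the limit leaves unreadable from compound 3 to compound 4.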

Compound 4, half-life: 2.23 h
For compound 4 the middle estimate is 1.8-fold (0.25 log units) above the measured one; low and high end bracket the measured number.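

In this assay, cyclopropyl in place of ethoxy on an aromatic carbon gives an at least 1.1-fold lower number from compound 3 to compound 4 (0.04 log units; that floor lies within the scatter), whereas the same change between compound 2 and compound 1 gives a step that cannot be read. Methyl in place of ethoxy gives an at least 1.1-fold lower number from compound 2 to compound 4 (0.04 log units; that floor lies within the scatter), and methyl in place of cyclopropyl gives an at least 1.1-fold lower number from compound 1 to compound 4 (0.04 log units; that floor lies within the scatter). The result therefore shows neither that the change carries from one core to the other nor that it fails to, and the true sizes of these steps remain unknown because the other readings stop at a limit: the limit of > 2.5 h in this assay, at which 3 of the 4 values shown sit.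

The compounds shown leave open how the half-life would respond to an amine or a carboxylic acid on either ring. They also leave open the effect of a longer chain in place of the linker.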